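Trading the ester chain for a dipropylcarbamate

The compounds below may be only part of what the source reports. "The series", "measured", "known", "first", "only" and "open" are said of these compounds alone.

Four compounds share one core, a ring bearing two trimethoxybenzoyl groups, and differ only in the group attached through an ester oxygen on a side chain. Compound 1 `CCCCCC(=O)OCC1CN(C(=O)c2cc(OC)c(OC)c(OC)c2)CCN1C(=O)c1cc(OC)c(OC)c(OC)c1` carries a pentyl chain on that carbonyl carbon; in a functional assay (Oryctolagus cuniculus) for inhibition of platelet-activating factor receptor (Cavia porcellus) (on this read-out lower numbers stand for stronger inhibition and higher numbers for weaker inhibition), compound 1 gives 290 nM. Compound 3 `COc1cc(C(=O)N2CCN(C(=O)c3cc(OC)c(OC)c(OC)c3)C(COC(=O)CC(C)(C)C)C2)cc(OC)c1OC` carries a tert-butyl group at the same position, and in this assay compound 3 gives 120 nM. Compound 2 `CCC(CC)C(=O)OCC1CN(C(=O)c2cc(OC)c(OC)c(OC)c2)CCN1C(=O)c1cc(OC)c(OC)c(OC)c1` carries a branched chain and in this assay compound 2 gives 70 nM; 40 nM; 60 nM (3 entries). Among the compounds with a single number, compound 1 stands highest, and its only single-number neighbour is compound 3.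

Among the compounds with values here, the one measured step that bears on a change at this carbonyl carbon is a 2.4-fold lower number from compound 1 to compound 3 (0.38 log units; beyond the scatter). The branched chain of compound 2 points the same way, as seen in the several entries of compound 2 in this assay, 70 nM; 40 nM; 60 nM (3 entries).

Compound 4 `CCCN(CCC)C(=O)OCC1CN(C(=O)c2cc(OC)c(OC)c(OC)c2)CCN1C(=O)c1cc(OC)c(OC)c(OC)c1` differs from compound 1 by dipropylamino in place of pentyl on a carbonyl carbon. Within the data shown here, no measured step replaces an ester by a carbamate, so this change is not directly covered; the lower numbers of compound 2 and compound 3 next to compound 1 suggest that a changed group on this carbonyl carbon tends toward lower numbers. A modest lowering is therefore expected, about a 1.9-fold lower number from compound 1 to compound 4 (0.29 log units; within the scatter), and compound 4 is estimated at 150 nM, within a range from 50 nM to 450 nM.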

Compound 4, half-maximal inhibitory concentration: 380 nM
For compound 4 the middle estimate is 2.5-fold (0.40 log units) below the measured one; measured number inside the range.
By their numbers in this assay, from the lowest: compound 3; then compounds 1 and 4 (each within the scatter of the next).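

In this assay, dipropylamino in place of pentyl on the carbonyl carbon gives a 1.3-fold higher number from compound 1 to compound 4 (0.12 log units; within the scatter), so this change leaves the number within the usual scatter, even though the entering group brings a nitrogen and more heavy atoms. Set against the neopentyl group of compound 3, the same group gives a 3.2-fold higher number from compound 3 to compound 4 (0.50 log units; beyond the scatter), which shows that the group on this carbonyl carbon can matter and that compound 4 goes against the earlier picture of changed groups here giving lower numbers. The branched chain of compound 2 also stays lower than compound 4 in every entry, so a change at this position does not carry a single direction: the several entries of compound 2 in this assay, 70 nM; 40 nM; 60 nM (3 entries)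

The compounds shown leave open whether the nitrogen attached to the carbonyl carbon or the two propyl chains set compound 4 apart from compound 3, a question that a smaller dimethylamino group on the same carbon would help to separate. They also leave open how a carbamate with a branched group such as diisopropylamino, or an ester chain ending in an amine or a carboxylic acid, would read in this assay.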